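Furan-Bearing Hydrazone Awaits Its Cytotoxicity Reading

A few compounds are considered here, and "the series" means these few. Any claim that something is new, unique, unknown or untested is made for them only; others in the source may bear on it.

Compound 1 `Cc1nc2cc(C(=O)NN)c([N+](=O)[O-])cc2[nH]1`: > 100000 nM in a functional assay on MCF7 cells (Homo sapiens) for cytotoxicity, read by resazurin assay, with a stated time of 72 h; on this read-out higher numbers stand for weaker inhibition and lower numbers for stronger inhibition
Compound 2 `CC(C)=NNC(=O)c1cc2nc(C)[nH]c2cc1[N+](=O)[O-]`: > 100000 nM in this assay

The value given for compound 1 is a limit of the assay, not a number. The value given for compound 2 is likewise a limit. Compound 2 therefore stands at the limit of > 100000 nM in this assay, at which 2 of the 2 values shown sit, and the step that the two limits leave unreadable from compound 1 to compound 2 cannot be read from two limits. Compound 3 `Cc1nc2cc(C(=O)N/N=C\c3ccco3)c([N+](=O)[O-])cc2[nH]1` differs from compound 2 by a group of 7 heavy atoms (5 carbon, 1 nitrogen, 1 oxygen; one five-membered aromatic ring with 1 hetero atom) in place of a group of 4 heavy atoms (3 carbon, 1 nitrogen; no ring), on an amide-type nitrogen. Among the measured compounds shown here, since the only step measured in this assay is unreadable, no size of step can be drawn from it for the change to compound 3, and any expectation rests on two limits alone. Compound 3 is expected to sit near the same limit, giving an estimated 80000 nM (range 15000 nM to 300000 nM). The expected step is an at least 1.2-fold lower number from compound 2 to compound 3 (0.09 log units; that floor lies within the scatter), which is no more than a guess of no movement beyond the scatter.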

Compound 3, half-maximal inhibitory concentration: 81000 nM
Compound 3: middle estimate off by 1.0-fold (0.01 log units), on the low side; the measured number falls inside the stated range.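

In this assay compound 3 is the only compound shown that gives a number and not a limit of the assay: the limit of > 100000 nM in this assay, at which 2 of the 3 values shown sit. With the group carrying one five-membered aromatic ring with 1 hetero atom on the amide-type nitrogen, the change can now be stated as a floor, namely an at least 1.2-fold lower number from compound 2 to compound 3 (0.09 log units; that floor lies within the scatter), and likewise an at least 1.2-fold lower number from compound 1 to compound 3 (0.09 log units; that floor lies within the scatter). Both floors lie within the scatter, so neither step establishes a real difference in cytotoxicity, and the true size of each remains hidden behind the limits.

As far as these compounds go, whether a phenyl ring, a thiophene ring or a longer chain on the same nitrogen would give a number clearly apart from that of compound 3 stays open. Also open, from the compounds shown here alone, is whether an amine on this nitrogen's group would do so.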